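Swapping hydroxy for fluoromethyl on the chain of compound 3

The source may report more compounds than this note shows. Statements on the series, on what has been measured and on what is new or still open speak of the compounds shown alone.

In a physicochemical assay for solubility, measured as kinetic solubility (on this read-out lower numbers stand for lower solubility and higher numbers for higher solubility), compound 3 `Cc1ccccc1N1C(=O)/C(=C/c2ccc(O)c(Cl)c2)S/C1=N\CCO` gives > 250000 nM, a limit of the assay and not a number. The next structure, compound 4 `Cc1ccccc1N1C(=O)/C(=C/c2ccc(O)c(Cl)c2)S/C1=N\CCCF`, differs from it by fluoromethyl in place of hydroxy on a saturated chain carbon, two bonds along the chain from a double-bonded nitrogen. Cut one bond further out, the same difference reads 2-hydroxyethyl to 3-fluoropropyl. The rest of the structure is unchanged.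

Exact numbers exist for two other compounds: compound 1 `CCC/N=C1\S/C(=C\c2ccc(O)c(Cl)c2)C(=O)N1C1CCS(=O)(=O)CC1` gives 75000 nM and compound 2 `CCC/N=C1\S/C(=C\c2ccc(O)c(Cl)c2)C(=O)N1C1CCOCC1` gives 70000 nM. For the measured compounds named here, the one measured step is a 1.1-fold lower number from compound 1 to compound 2 (0.03 log units; within the scatter). That step lies on an amide-type nitrogen in a ring, not on the chain, so it bears on the present change only indirectly. Going by the values given here, no measured step covers a change at this chain position.

The expectation therefore rests on the exact numbers of compound 1 at 75000 nM and compound 2 at 70000 nM, which carry a propyl chain without hydroxy. The expected change is an at least 5.5-fold lower number from compound 3 to compound 4 (0.74 log units; beyond the scatter), towards a lower number, and its size stays loose since the starting point is only a limit. Compound 4 is estimated at 45000 nM, with an expected range of 12000 nM to 130000 nM.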

Compound 4, solubility: 20000 nM
The estimate for compound 4 lay 2.3-fold (0.35 log units) above the measured number; measured number inside the range.
By their numbers in this assay, from the lowest: compound 4; then compounds 2 and 1 (each within the scatter of the next). At a limit, above all of these: compound 3.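

In this assay this chain position proves responsive: the series now holds an at least 12-fold lower number from compound 3 to compound 4 (1.09 log units; beyond the scatter), the first step shown that lies beyond the scatter. The only earlier step, a 1.1-fold lower number from compound 1 to compound 2 (0.03 log units; within the scatter), sits on an amide-type nitrogen in a ring and lies within the scatter, so among these four compounds a single change has moved the number at the chain position and not at the ring position. The new step gives only a minimum size and not a measured gap, since compound 3 stands at a limit of the assay and not at a number: the limit of > 250000 nM in this assay, at which 1 of the 4 values shown sits.

The step from 2-hydroxyethyl to 3-fluoropropyl changes the chain length and the group it carries together, so the compounds shown do not tell how much of the drop belongs to each. A 3-hydroxypropyl chain would separate the two, and an amine in place of the hydroxy would show whether the high value of compound 3 is particular to hydroxy.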